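This account rests on a few compounds, and the source may have more. Where it says the series, first, only, none or still open, it means among the compounds named here.

Measured so far:
Compound 1 `Cn1nccc1-c1cc(C(F)(F)F)ccc1[C@H]1CCOc2cc(S(=O)(=O)Nc3nccs3)ccc21`: 83000 nM
Compound 2 `Cn1nccc1-c1cc(C(F)(F)F)ccc1[C@H]1CCOc2cc(S(=O)(=O)Nc3ncccn3)ccc21`: 532000 nM
Compound 3 `Cn1nccc1-c1cc(C(F)(F)F)ccc1[C@@H]1CCOc2cc(S(=O)(=O)Nc3nccs3)ccc21`: 65000 nM

In a physicochemical assay for solubility (a lower number here means a less soluble compound, a higher number a more soluble compound), compound 1 sits within the scatter of its mirror-drawn partner, a 1.3-fold lower number from compound 1 to compound 3 (0.11 log units; within the scatter), and well short of the top number, a 6.4-fold higher number from compound 1 to compound 2 (0.81 log units; beyond the scatter). Compound 4 `O=S(=O)(Nc1nccs1)c1ccc2c(c1)OCC[C@@H]2c1ccc(C(F)(F)F)cc1-c1nccs1` is still unmeasured, and it changes a different place: 1,3-thiazol-2-yl in place of 1-methyl-1H-pyrazol-5-yl on an aromatic carbon. Going by the values given here, no measured step touches that place. The step of a 1.3-fold lower number from compound 1 to compound 3 (0.11 log units; within the scatter) reflects (the fact that compounds 1 and 3 differ only in the configuration as drawn), so it offers little guidance. The step of a 6.4-fold higher number from compound 1 to compound 2 (0.81 log units; beyond the scatter) removed a 1,3-thiazol-2-yl group from the sulfonamide nitrogen, which weakly suggests that adding one elsewhere lowers the number. A modest drop is therefore expected, namely a 2.1-fold lower number from compound 1 to compound 4 (0.32 log units; beyond the scatter). For compound 4 the estimated value is 40000 nM, with an expected range of 12000 nM to 120000 nM.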

Compound 4, solubility: 15000 nM
Compound 4: the middle estimate sits 2.7-fold (0.43 log units) above what was measured; the range from low to high includes it.
By their numbers in this assay, from the lowest: compound 4; then compounds 3 and 1 (each within the scatter of the next); then compound 2.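

Swapping 1-methyl-1H-pyrazol-5-yl for 1,3-thiazol-2-yl on this aromatic carbon shows that this place also matters in this assay, giving a 5.5-fold lower number from compound 1 to compound 4 (0.74 log units; beyond the scatter). Both groups are five-membered aromatic rings with the same counts of donors and acceptors, so matching those counts did not keep the number in place. Nothing available explains why the number falls with this swap.

As far as these compounds go, it remains open how other groups on this carbon, such as an amine or a carboxylic acid, would behave, and whether the drop would persist with pyrimidin-2-yl on the sulfonamide nitrogen.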